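Exchanging 4-chlorophenoxy for 3,5-dimethylbenzyl on the shared core

The compounds below may be only part of what the source reports. "The series", "measured", "known", "first", "only" and "open" are said of these compounds alone.

In an ADME assay on HepG2 cells (Homo sapiens) for cytotoxicity, read by luminescence, CellTiter-Glo and ATP content, with a stated time of 72 h (a lower number here means that less compound is needed, a higher number that more compound is needed for the effect), compound 1 `COc1cccc(CNCCCNc2ccnc3cc(Oc4ccc(Cl)cc4)ccc23)c1O` gives 5700 nM. Compound 2 `COc1ccc(-c2ccc3c(NCCCNCc4ccco4)ccnc3c2)cc1` gives 6000 nM, and compound 3 `Clc1ccc(Oc2ccc3c(NCCCNCc4ccco4)ccnc3c2)cc1` gives 7800 nM. Compound 1 thus carries the smallest of the three numbers, though its gaps to compound 2 and to compound 3 both fall within the scatter. Compound 4 `COc1cccc(CNCCCNc2ccnc3cc(Cc4cc(C)cc(C)c4)ccc23)c1O` differs from compound 1 in one place: 3,5-dimethylbenzyl in place of 4-chlorophenoxy on an aromatic carbon. For the measured compounds named here, two measured steps bear on this. The step in which the 4-chlorophenoxy group was likewise exchanged, a 1.3-fold higher number from compound 2 to compound 3 (0.11 log units; within the scatter), stayed within the scatter, as did a 1.4-fold higher number from compound 1 to compound 3 (0.14 log units; within the scatter) on the amine side of the chain. With both prior changes leaving the read-out unmoved, no step beyond the scatter is expected, and a 1.1-fold higher number from compound 1 to compound 4 (0.02 log units; within the scatter) is the estimated outcome. Compound 4 is therefore expected to give 6000 nM, within a range of 2500 nM to 14000 nM.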

Compound 4, half-maximal effective concentration: 2680 nM
Compound 4: the middle estimate sits 2.2-fold (0.35 log units) above what was measured, within the range that was stated.
By their numbers in this assay, from the lowest: compound 4; then compounds 1, 2 and 3 (each within the scatter of the next).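

In this assay, the exchange of 4-chlorophenoxy for 3,5-dimethylbenzyl gives a 2.1-fold lower number from compound 1 to compound 4 (0.33 log units; beyond the scatter), a modest shift and the only step shown beyond the scatter. This position can therefore move the read-out, although the exchange of 4-methoxyphenyl for 4-chlorophenoxy did not show this. Nothing measured here accounts for the shift. From the compounds shown here alone, it remains open whether the step follows the loss of the oxygen, the loss of the chlorine or the gain of the two methyl groups, and whether an unsubstituted benzyl or a 4-chlorobenzyl group would give the same step.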